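This account rests on a few compounds, and the source may have more. Where it says the series, first, only, none or still open, it means among the compounds named here.

Notes on the series, read in a functional assay on the whole organism (strain Sprague-Dawley) for inhibition, with Rattus norvegicus as the target, with a stated time of 10 min; on this read-out lower numbers stand for an effect already at smaller amounts and higher numbers for an effect only at larger amounts of compound. Compound 2 `COc1nc(-c2ccccc2)ncc1C(=O)O` gives > 10 mg/kg, which is a limit and not a number. Compound 3 `CCOC(=O)c1cnc(-c2ccccc2)nc1OC` gives > 5 mg/kg, which is also a limit. Among the compounds with values here, the only measured single-place change is a step that the two limits leave unreadable from compound 2 to compound 3, so it offers no size to carry forward, and it concerns the acid oxygen rather than the aromatic carbon at issue here.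

Compound 4 `CCOc1ccccc1-c1ncc(C(=O)O)c(OC)n1` is reached from compound 2 by ethoxy in place of hydrogen on an aromatic carbon. Within the data shown here, no measured step covers this change. Among the measured compounds shown here, the only compound with a true number is compound 1 `CC(C)Oc1ccccc1-c1ncc(C(=O)O)c(=O)[nH]1`, at 0.8 mg/kg in this assay, and the expected direction, towards effect at smaller doses, rests on that value alone. Its size remains poorly fixed, and compound 4 may also end up reported only as a limit.

The expected change is an at least 3.3-fold lower number from compound 2 to compound 4 (0.52 log units; beyond the scatter). For compound 4 the estimate is 3 mg/kg, with an expected range of 0.8 mg/kg to 12 mg/kg.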

Compound 4, dose for 50% inhibition: > 5 mg/kg
Compound 4: a limit, no number (the forecaster's own chance of this, stated with the estimate: 35%); middle value at least 1.6-fold (0.22 log units) from the limit.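

Within the data shown here, compound 2 and compound 4 are both reported only as limits and not as numbers, so no step between them can be read. The compounds shown leave open whether ethoxy in place of hydrogen on an aromatic carbon changes the read-out at all, and in which direction.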